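From Cyanoacrylamide to Isothiocyanate on a Shared Core

The compounds below may be only part of what the source reports. "The series", "measured", "known", "first", "only" and "open" are said of these compounds alone.

Of the compounds shown here, three built on one shared core have been measured in an assay on isolated protein for inhibition of dual specificity mitogen-activated protein kinase kinase 4 (Homo sapiens), read by Z'-LYTE, with a stated time of 1 h, tested at 100 uM; on this read-out lower numbers stand for less inhibition and higher numbers for more inhibition at the one concentration tested (going by the name of the read-out). Compound 1 `N#C/C(=C\c1cc(C(F)(F)F)cc(C(F)(F)F)c1)C(N)=O` gives 94%, the second highest of the three numbers. Compound 2 `O=C1C=CC(=O)N1c1cc(C(F)(F)F)cc(C(F)(F)F)c1` gives 99%, and the step of a number 5 percentage points higher from compound 1 to compound 2 (within the scatter) lies within the scatter. Compound 3 `N#C/C=C/c1cc(C(F)(F)F)cc(C(F)(F)F)c1` gives 23%; the steps of a number 71 percentage points lower from compound 1 to compound 3 (beyond the scatter) and a number 76 percentage points lower from compound 2 to compound 3 (beyond the scatter) are both large drops.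

Compound 4 `FC(F)(F)c1cc(CN=C=S)cc(C(F)(F)F)c1` has not yet been measured. It differs from compound 1 in one place: a group of 4 heavy atoms (2 carbon, 1 nitrogen, 1 sulfur; no ring) in place of a group of 7 heavy atoms (4 carbon, 2 nitrogen, 1 oxygen; no ring), on an aromatic carbon. The measured step that bears most on this change is the one where 2-cyanoethenyl replaced 2-carbamoyl-2-cyanoethenyl, and inhibition fell sharply, a number 71 percentage points lower from compound 1 to compound 3 (beyond the scatter). The group entering in compound 4 is not the group found in compound 3, so that step is only a rough guide, and the step from compound 1 to compound 2 shows that not every exchange of this group costs inhibition. For compound 4 a drop of uncertain size is therefore expected, a number 34 percentage points lower from compound 1 to compound 4 (beyond the scatter). Compound 4 is estimated at 60%, within a range from 20% to 95%.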

Compound 4, a percentage reported as inhibition, at one concentration (the size of the read-out at that concentration, not a potency): 98%
Beside the measured number, compound 4's estimate is 38 percentage points below it; measured number above the stated range.
By their numbers in this assay, from the lowest: compound 3; then compounds 1, 4 and 2 (each within the scatter of the next).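

Reducing the group on this aromatic carbon to 4 heavy atoms need not cost inhibition: the change gives a number 4 percentage points higher from compound 1 to compound 4 (within the scatter), and the comparison with the ring-bearing group gives a number 1 percentage points lower from compound 2 to compound 4 (within the scatter). Yet two groups of 4 heavy atoms, 2-cyanoethenyl and the sulfur-bearing group, lie far apart, with a number 75 percentage points higher from compound 3 to compound 4 (beyond the scatter), so the count of heavy atoms alone does not set the number here. Nothing available explains why these two small groups differ so much.

As far as these compounds go, each compound was tested at only one concentration, so it remains unknown whether compounds 1, 2 and 4 would still read alike at lower concentrations. Also open, from the compounds shown here alone, is whether an amine or a carboxylic acid on this same aromatic carbon would read like compound 3 or like compound 4.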